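A few compounds are considered here, and "the series" means these few. Any claim that something is new, unique, unknown or untested is made for them only; others in the source may bear on it.

Of the compounds shown here, three built on one shared core have been measured in a functional assay on CHO cells for positive allosteric modulation of metabotropic glutamate receptor 2 (Homo sapiens), with a stated time of 30 min; a lower number here means that less compound is needed, a higher number that more compound is needed for the effect. Compound 1 `CC(C)CCn1ccc(CCc2ccccc2)c(C#N)c1=O` gives 361 nM. Compound 2 `CC(C)CCn1ccc(N2CCC(c3ccccc3)CC2)c(C#N)c1=O` gives 102 nM, the lowest of the three numbers; its nearest neighbour is compound 1, and its furthest is compound 3 `CC(C)CCn1ccc(N2CCCCC2)c(C#N)c1=O`, which gives 31600 nM. Among the compounds with values here, the one step in which two measured structures differ in a single place is a 310-fold higher number from compound 2 to compound 3 (2.49 log units; beyond the scatter), a large loss when the phenyl on the saturated ring is taken away.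

Compound 4 `CCCCn1ccc(N2CCC(c3ccccc3)CC2)c(C#N)c1=O` has not yet been measured. It differs from compound 2 by hydrogen in place of methyl on a saturated chain carbon bound to two saturated chain carbons; read one bond further out, the same difference is isopentyl to butyl. Within the data shown here, no measured step touches this chain, so the change stands without a direct precedent. Among the measured compounds shown here, the only measured step concerns a different part of the molecule, and the phenyl-bearing ring of compound 2 stays in place in compound 4. A step no larger than the usual scatter is therefore expected, with no clear direction. The estimated step is a 1.5-fold higher number from compound 2 to compound 4 (0.17 log units; within the scatter). Compound 4 is expected to give about 150 nM, between 50 nM and 500 nM, in this assay.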

Compound 4, half-maximal effective concentration: 95 nM
Compound 4: the middle estimate sits 1.6-fold (0.20 log units) above what was measured; low and high end bracket the measured number.
By their numbers in this assay, from the lowest: compounds 4 and 2 (each within the scatter of the next); then compound 1; then compound 3.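

Taking the methyl off the chain, which turns isopentyl into butyl, gives a 1.1-fold lower number from compound 2 to compound 4 (0.03 log units; within the scatter) in this assay, so the two compounds cannot be told apart in this read-out. Within the data shown here, this is the first measured look at the chain, and it shows that on the core of compound 2 this one carbon can go without a step beyond the scatter, whereas taking away the phenyl on the saturated ring gave a 310-fold higher number from compound 2 to compound 3 (2.49 log units; beyond the scatter). The branch in the isopentyl chain is therefore not needed for the number seen with compound 2, although this rests on a single pair, and no measurement at hand explains why the chain and the phenyl differ so much.

The compounds shown leave open how far this tolerance reaches, since a longer chain such as hexyl, a cyclopropylmethyl group, or a chain ending in an amine or a carboxylic acid could read quite differently. They also leave open whether the same swap from isopentyl to butyl would read alike on the core of compound 1, which carries no saturated ring.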